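The compounds below may be only part of what the source reports. "The series", "measured", "known", "first", "only" and "open" are said of these compounds alone.

Compound 1 `COc1cc(C(c2ccc(O)c(OC)c2)[C@@H](C)C(C)C)ccc1O` gives 19000 nM
Compound 2 `COc1cc(C(c2ccc(O)c(OC)c2)[C@H](C)[C@@H](C)CO)ccc1O` gives > 100000 nM (a limit of the assay)

Both compounds were tested in a functional assay on HeLa cells (Homo sapiens) for cytotoxicity, read by WST assay, with a stated time of 48 h; a higher number here means a weaker inhibitor, a lower number a stronger inhibitor. As far as these compounds go, compound 2 has only the limit > 100000 nM, so its exact place on the scale is unknown. Compound 3 `COc1cc(C(c2ccc(O)c(OC)c2)[C@H](C)[C@H](C)CF)ccc1O` keeps the shared core and changes one end of the chain: 1-(fluoromethyl)ethyl in place of 1-(hydroxymethyl)ethyl on a saturated chain carbon bound to two saturated chain carbons. Put simply, 1-(fluoromethyl)ethyl replaces 1-(hydroxymethyl)ethyl.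

Within the data shown here, only one measured step bears on this change. Replacing 1,2-dimethylpropyl with 2-(hydroxymethyl)-1-methylpropyl gave an at least 5.2-fold higher number from compound 1 to compound 2 (0.72 log units; beyond the scatter). Compound 3 no longer has the hydroxymethyl group, so it is expected to regain part of that step, though one step is thin evidence. The expected change is an at least 2.5-fold lower number from compound 2 to compound 3 (0.39 log units; beyond the scatter), towards a lower number. The estimate for compound 3 is 40000 nM, with an expected range from 13000 nM to 100000 nM.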

Compound 3, half-maximal inhibitory concentration: 75000 nM
Estimate against measurement, compound 3: 1.9-fold (0.27 log units) below; measured number inside the range.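

In this assay, fluoromethyl in place of hydroxymethyl at the chain end gives an at least 1.3-fold lower number from compound 2 to compound 3 (0.12 log units; that floor lies within the scatter), so the data cannot show that this swap changes the number at all. The new information comes from the other comparison, a 3.9-fold higher number from compound 1 to compound 3 (0.60 log units; beyond the scatter): the higher number relative to compound 1 is not confined to the hydroxymethyl group, since it also appears with a fluoromethyl end, which has no hydrogen-bond donor. The true size of the step from hydroxymethyl to fluoromethyl stays unknown because compound 2 has only a limit: the limit of > 100000 nM in this assay, at which 1 of the 3 values shown sits.

The compounds shown leave open how an aminomethyl group, a carboxylic acid or a longer chain at this end would compare with compound 1. They also cannot tell why both replacements of the plain 1,2-dimethylpropyl end give a higher number.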